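This account rests on a few compounds, and the source may have more. Where it says the series, first, only, none or still open, it means among the compounds named here.

Working notes on the series. Three compounds share one macrocyclic core. Compound 1 `CO[C@H]1C[C@H](C)Cc2cc(O)cc(c2)NC(=O)/C=C/CC[C@H](OC)[C@@H](OC(N)=O)/C(C)=C/[C@H](C)[C@H]1O` is taken in a functional assay on A549 cells (Homo sapiens) for inhibition; a higher number here means a weaker inhibitor of growth, a lower number a stronger inhibitor of growth; compound 1 gives only a limit there, > 10000 nM (the limit of > 10000 nM in this assay, at which 1 of the 3 values shown sits). Compound 2 `COc1c2cc(cc1OC(C)=O)NC(=O)/C(C)=C/CC[C@H](OC)[C@@H](OC(N)=O)/C(C)=C/[C@H](C)[C@@H](O)[C@@H](OC)C[C@H](C)C2` gives 3550 nM in this assay. For the measured compounds named here, compound 3 `CO[C@H]1C[C@H](C)Cc2cc(cc(O)c2O)NC(=O)/C(C)=C/CC[C@H](OC)[C@@H](OC(N)=O)/C(C)=C/[C@H](C)[C@H]1O` gives 10300 nM in this assay, the highest of the two numbers known, with compound 2 the nearest value. The unmeasured compound 4 `COc1c(O)cc2cc1C[C@@H](C)C[C@H](OC)[C@H](O)[C@@H](C)/C=C(\C)[C@H](OC(N)=O)[C@@H](OC)CC/C=C(\C)C(=O)N2` differs from compound 3 by methyl in place of hydrogen on an oxygen on an aromatic ring. Going by the values given here, no measured pair differs in one place only, so no size of step is known for this change; for this assay a small step, if any, is expected, with no clear direction beyond the scatter. For compound 4 the estimate is 7000 nM in this assay, range 2500 nM to 20000 nM, corresponding to an expected step of a 1.5-fold lower number from compound 3 to compound 4 (0.17 log units; within the scatter).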

Compound 4, concentration for 50% growth inhibition: 2720 nM
Beside the measured number, compound 4's estimate is 2.6-fold (0.41 log units) above it, within the range that was stated.
By their numbers in this assay, from the lowest: compounds 4 and 2 (each within the scatter of the next); then compound 3.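

On an oxygen on an aromatic ring, hydroxy to methoxy in this assay gives the first single-place step read at this position, a modest one beyond the scatter (a 3.8-fold lower number from compound 3 to compound 4 (0.58 log units; beyond the scatter)). At the same kind of position, hydrogen in place of acetyl gives a step within the scatter (a 1.3-fold lower number from compound 2 to compound 4 (0.12 log units; within the scatter)). No measurement shown gives a cause for either step.

Open, from the compounds shown here alone, is whether a longer chain on that oxygen, such as ethoxy, continues the step seen with methyl. Also open, going by these compounds, is what an amine in place of the hydroxy would give.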